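The source may report more compounds than this note shows. Statements on the series, on what has been measured and on what is new or still open speak of the compounds shown alone.

Compound 1 `CC(C)c1cccc(C(C)C)c1OS(=O)(=O)NC(=O)Oc1cccnc1`: in an assay on liver for inhibition of sterol O-acyltransferase 1 (Rattus norvegicus), using microsomes (on this read-out lower numbers stand for stronger inhibition and higher numbers for weaker inhibition), compound 1 gives > 50000 nM, which is a limit of the assay.
Compound 2 `CC(C)c1cccc(C(C)C)c1OS(=O)(=O)NC(=O)Oc1ccc(F)cc1F`: in this assay compound 2 gives > 50000 nM, likewise a limit of the assay.

Compound 2 therefore stands only at a limit. The step from compound 1 to compound 2 a step that the two limits leave unreadable from compound 1 to compound 2 cannot be read because both values sit at the limit of > 50000 nM in this assay, at which 2 of the 2 values shown sit. Compound 3 `CC(C)c1cccc(C(C)C)c1OS(=O)(=O)NC(=O)Oc1c(F)cccc1F` differs from compound 2 by 2,6-difluorophenyl in place of 2,4-difluorophenyl on an oxygen next to a carbonyl group. Among the compounds with values here, no measured step bears on this change, so nothing beyond the scatter is expected in this assay, and compound 3 is expected to give 50000 nM, within 20000 nM to 200000 nM. The expected step from compound 2 to compound 3 is a number no higher from compound 2 to compound 3 (the limit leaves the size open).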

Compound 3, half-maximal inhibitory concentration: 65000 nM
For compound 3 the middle estimate is 1.3-fold (0.11 log units) below the measured one; the range from low to high includes it.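

The steps from compound 1 and compound 2 to compound 3 cannot be read, since each starts from a limit: the limit of > 50000 nM in this assay, at which 2 of the 3 values shown sit.

The compounds shown leave open how far the pyridin-3-yl, 2,4-difluorophenyl and 2,6-difluorophenyl groups truly differ in this assay.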